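The source may report more compounds than this note shows. Statements on the series, on what has been measured and on what is new or still open speak of the compounds shown alone.

Compound 1 `O=C(/C=C/c1ccc(O)cc1)c1c(O)cccc1OCCC1CCCC1` gives 3340 nM in a functional assay on MDA-MB-231 cells (Homo sapiens) for antiproliferative activity, read by sulforhodamine B assay; a higher number here means a weaker inhibitor of growth, a lower number a stronger inhibitor of growth. Compound 2 `CC(C)(C)CCOc1cccc(O)c1C(=O)CCc1ccc(O)cc1` reaches only the limit of this assay, at > 30000 nM, which is a boundary rather than a number.

Compound 1 therefore stands as the only one of the two with a measured number, the other value being a limit (the limit of > 30000 nM in this assay, at which 1 of the 2 values shown sits). Among the measured compounds shown here, no step between measured compounds can be drawn from these two, so the pair shows only that compound 1 has a number and compound 2 does not.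

Compound 3 `CCCCOc1cccc(O)c1C(=O)/C=C/c1ccc(O)cc1` differs from compound 1 in one place: ethyl in place of cyclopentyl on a saturated chain carbon, two bonds along the chain from an oxygen on an aromatic ring. For the measured compounds named here, with no measured step to lean on, the size of the change from compound 1 to compound 3 in this assay is open; a modest weakening, of an order not far beyond the scatter, is expected, written as a 1.8-fold higher number from compound 1 to compound 3 (0.25 log units; within the scatter). Compound 3 is estimated at 6000 nM, in the range 1500 nM to 25000 nM.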

Compound 3, concentration for 50% growth inhibition: > 30000 nM
Compound 3: no number, only a limit; the forecaster's own chance of this, stated with the estimate: 20%; at least 5.0-fold (0.69 log units) between middle value and limit.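

In this assay, among the compounds shown here, the change from 2-cyclopentylethoxy to butoxy gives an at least 8.9-fold higher number from compound 1 to compound 3 (0.95 log units; beyond the scatter), the first step that can be read at this position. Compound 3 gives > 30000 nM, which is a limit and not a number, so the step fixes only a minimum size for the change and not its true size. Even so, the step shows that this position does not tolerate every change: with ethyl in place of cyclopentyl, the measurable growth inhibition of compound 1 is lost within the range of this assay.

As far as these compounds go, it remains open whether the ring itself or only the size of the group matters, which a longer chain or a cyclohexyl ring at this place could help to separate. How far activity falls also stays unknown, and compound 1 remains the only one with a number: the limit of > 30000 nM in this assay, at which 2 of the 3 values shown sit.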